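Notes on compound 4: trifluoromethyl in place of cyano

The source may report more compounds than this note shows. Statements on the series, on what has been measured and on what is new or still open speak of the compounds shown alone.

In an ADME assay on L6 cells (Rattus norvegicus) for cytotoxicity, read by resazurin assay, with a stated time of 70 h (a higher number here means a weaker inhibitor, a lower number a stronger inhibitor), compound 1 (`CC(=O)Oc1ccc2c(c1)C(C)=CC(C)(C)N2Cc1ccc(C#N)cc1`) gives 29000 nM. Compound 2 (`CC(=O)Oc1ccc2c(c1)C(C)=CC(C)(C)N2Cc1cccc(C#N)c1`) gives 31000 nM, and compound 3 (`CC(=O)Oc1ccc2c(c1)C(C)=CC(C)(C)N2Cc1ccc(Cl)c(Cl)c1`) gives 28000 nM. Compound 1 therefore sits level with both of the other measured compounds, and the three cannot be ranked.

Compound 4 (`CC(=O)Oc1ccc2c(c1)C(C)=CC(C)(C)N2Cc1ccc(C(F)(F)F)cc1`) keeps the core of compound 1 and carries trifluoromethyl in place of cyano on an aromatic carbon, para to a large group: trifluoromethyl in place of cyano on an aromatic carbon.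

Among the measured compounds shown here, three measured steps bear on this change. The nearest is a 1.0-fold lower number from compound 1 to compound 3 (0.02 log units; within the scatter), where the 4-cyanophenyl group is also replaced. Moving the nitrile gives a 1.1-fold higher number from compound 1 to compound 2 (0.03 log units; within the scatter), and the remaining pair gives a 1.1-fold lower number from compound 2 to compound 3 (0.04 log units; within the scatter). All three stay within the scatter. For the measured compounds named here, no measured compound carries trifluoromethyl, so the group itself is untested. Going by the values given here, with these small steps as the only guide, no step beyond the scatter is expected in this assay, in either direction.

The estimated step is a 1.0-fold lower number from compound 1 to compound 4 (0.02 log units; within the scatter). The expected value for compound 4 is 28000 nM, with an estimated range of 16000 nM to 45000 nM.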

Compound 4, half-maximal inhibitory concentration: 14000 nM
Beside the measured number, compound 4's estimate is 2.0-fold (0.30 log units) above it; the measured number lies below the stated range.
By their numbers in this assay, from the lowest: compounds 4, 3, 1 and 2 (each within the scatter of the next, the first and the last beyond it).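

In this assay, the three earlier steps all stay within the scatter, whereas replacing cyano with trifluoromethyl on this aromatic carbon, para to a large group, gives a step beyond it: a 2.1-fold lower number from compound 1 to compound 4 (0.32 log units; beyond the scatter). The step is modest, but it shows that the number can respond to a change of one group at this position, something the nitrile move and the 3,4-dichlorophenyl replacement did not reveal. The data contain no measurement that accounts for this step, so the result remains an observation about this one pair of compounds.

From the compounds shown here alone, what remains open is whether the step belongs to trifluoromethyl specifically or would also appear with other groups on the same aromatic carbon, such as a methyl, a methoxy, an amine or a carboxylic acid. Also unresolved is whether a hydroxyl in place of the acetate ester on the shared core would leave this step intact, as a single pair cannot show how far the effect of the trifluoromethyl change extends across the series.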